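Swapping the Tail Amine of a Triazole Carboxamide

A few compounds are considered here, and "the series" means these few. Any claim that something is new, unique, unknown or untested is made for them only; others in the source may bear on it.

Measured so far:
Compound 1, `COc1cc2c(Oc3ccc(NC(=O)c4nnn(-c5ccc(C)cc5)c4C(F)(F)F)cc3F)ccnc2cc1OCCCN1CCC(C)CC1` — in a functional assay on HT-29 cells (Homo sapiens) for cytotoxicity, read by MTT assay, with a stated time of 72 h (on this read-out lower numbers stand for stronger inhibition and higher numbers for weaker inhibition), compound 1 gives 1200 nM.
Compound 2, `COc1cc2c(Oc3ccc(NC(=O)c4nnn(-c5ccc(F)c(F)c5)c4C(F)(F)F)cc3F)ccnc2cc1OCCCN1CCC(C)CC1` — in this assay compound 2 gives 190 nM.

Compound 2 stands as the lower of the two numbers, with compound 1 above it by a margin that is beyond the scatter. Among the measured compounds shown here, the only measured step, a 6.3-fold lower number from compound 1 to compound 2 (0.80 log units; beyond the scatter), concerns the aryl group on the triazole nitrogen and leaves the rest of the shared core untouched.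

Compound 3, `COc1cc2c(Oc3ccc(NC(=O)c4nnn(-c5ccc(F)c(F)c5)c4C(F)(F)F)cc3F)ccnc2cc1OCCCN1CCN(C)CC1`, differs from compound 2 in a different region: 4-methylpiperazin-1-yl in place of 4-methylpiperidin-1-yl on a saturated chain carbon, three bonds along the chain from an oxygen on an aromatic ring. For the measured compounds named here, no measured step touches this tail, so the expectation rests on the core of compound 2 staying unchanged. A step of a 1.3-fold higher number from compound 2 to compound 3 (0.12 log units; within the scatter) is therefore expected in this assay, that is, none beyond the scatter. Compound 3 is estimated at 250 nM, with a range from 100 nM to 700 nM.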

Compound 3, half-maximal inhibitory concentration: 150 nM
Beside the measured number, compound 3's estimate is 1.7-fold (0.22 log units) above it; the measured number falls inside the stated range.
By their numbers in this assay, from the lowest: compounds 3 and 2 (each within the scatter of the next); then compound 1.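

In this assay, the exchange of 4-methylpiperidin-1-yl for 4-methylpiperazin-1-yl gives a 1.3-fold lower number from compound 2 to compound 3 (0.10 log units; within the scatter) and so does not separate compound 2 from compound 3 on this read-out. Among the compounds shown here, this is the first measured step at this place, on a saturated chain carbon, three bonds along the chain from an oxygen on an aromatic ring, and it shows that, with the 3,4-difluorophenyl group held fixed, this position accepts either ring. Nothing available accounts for this result.

On these data alone, whether the same exchange would read alike with the 4-methylphenyl group of compound 1 remains open. Also open, as far as these compounds go, is how this position would respond to a morpholine, a dimethylamino group or a shorter chain.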